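Swapping Fluoro for Cyano on the Outer Ring

This account rests on a few compounds, and the source may have more. Where it says the series, first, only, none or still open, it means among the compounds named here.

Compounds 1 to 3 share one core and differ only in the group on a six-membered aromatic ring of carbon only. Compound 1 `O=C(N/N=C/c1ccc(Cl)cc1)c1cnccn1` carries a chloro, compound 2 `O=C(N/N=C/c1ccccc1F)c1cnccn1` a fluoro, and compound 3 `O=C(N/N=C/c1ccc(O)cc1)c1cnccn1` a hydroxy. In an ADME assay on J774 cells (Mus musculus) for cytotoxicity, read by MTT assay, with a stated time of 48 h, tested at 50 ug/mL (on this read-out higher numbers stand for a weaker effect at the one concentration tested and lower numbers for a stronger effect), compound 1 gives 83%, compound 2 gives 100%, and compound 3 gives 100%. Compound 2 is level with compound 3 at the digits shown, the two together the highest of the three numbers, while compound 1 sits lower: a number 17 percentage points higher from compound 1 to compound 3 (beyond the scatter). Compound 4 `N#Cc1ccccc1/C=N/NC(=O)c1cnccn1` is the next step from compound 2: cyano in place of fluoro on an aromatic carbon. For the measured compounds named here, no measured step exchanges a fluoro for a cyano, so the only hint is the change from chloro to hydroxy, and that was modest. All three numbers sit near the top of the scale, and the expected step in this assay is a number 5 percentage points lower from compound 2 to compound 4 (within the scatter), none beyond the scatter. Compound 4 is therefore estimated at 95%, with a range from 80% to 100%.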

Compound 4, a percentage reported as activity, at one concentration (the size of the read-out at that concentration, not a potency): 92%
Compound 4: middle estimate off by 3 percentage points, on the high side, and the stated range covers the measured number.
By their numbers in this assay, from the lowest: compounds 1, 4, 2 and 3 (each within the scatter of the next, the first and the last beyond it).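

Placing a cyano where compound 2 carries a fluoro, on an aromatic carbon ortho to a large group, gives a number 8 percentage points lower from compound 2 to compound 4 (within the scatter) in this assay, and this is the first direct reading of that exchange. The position therefore accepts two heavy atoms with a triple bond and a hydrogen-bond acceptor in place of a single fluorine, without a difference that this read-out can separate from ordinary scatter. Nothing measured here offers an explanation for this outcome.

Going by these compounds, whether an amine, a carboxylic acid or a longer chain on this same carbon would also stay within the scatter of compound 2 remains open. Since each number comes from one concentration, these compounds also leave open how their cytotoxicity would change at higher concentrations.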